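A Nitro Group Where Chlorine Stood

This account rests on a few compounds, and the source may have more. Where it says the series, first, only, none or still open, it means among the compounds named here.

Compound 1 `CCn1c(/C=C2/C(=O)Nc3ccccc32)nc2ccccc21` is the starting point. In a functional assay on BT-549 cells (Homo sapiens) for cytotoxicity, read by MTT assay, with a stated time of 48 h (on this read-out higher numbers stand for weaker inhibition and lower numbers for stronger inhibition), compound 1 gives > 50000 nM, which is a limit of the assay rather than a number. Compound 2 `CCn1c(/C=C2/C(=O)Nc3ccc(Cl)cc32)nc2ccccc21` carries a chloro in place of a hydrogen on an aromatic carbon. In this assay compound 2 gives > 50000 nM, again a limit and not a number. The step from compound 1 to compound 2 is thus a step that the two limits leave unreadable from compound 1 to compound 2. On the numbers shown, compound 2 stands at the limit of > 50000 nM in this assay, at which 2 of the 2 values shown sit, and nothing places it more precisely.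

Compound 3 `CCn1c(/C=C2/C(=O)Nc3ccc([N+](=O)[O-])cc32)nc2ccccc21` is the next case: nitro in place of chloro on an aromatic carbon. Among the compounds with values here, only one measured step bears on it, a step that the two limits leave unreadable from compound 1 to compound 2, and since its size could not be read it gives no direction. No step beyond the scatter can therefore be expected in this assay. The expected step of a number no higher from compound 2 to compound 3 (the limit leaves the size open) mainly expresses how likely a number, rather than a further limit, is to appear. For compound 3 the estimate is 50000 nM, within 15000 nM to 150000 nM, with a further limit the likelier outcome.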

Compound 3, half-maximal inhibitory concentration: > 50000 nM
Compound 3: no number, only a limit; the forecaster's own chance of this, stated with the estimate: 80%; the middle value sits exactly at the limit.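

In this assay compound 3 gives > 50000 nM, a limit and not a number. No step from compound 1 or compound 2 to compound 3 can be read: the limit of > 50000 nM in this assay, at which 3 of the 3 values shown sit.

What the compounds shown leave open is how strongly any of the three acts on these cells, and whether hydrogen, chloro and nitro differ at all here.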